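Swapping the Aryl Urea Substituent on a Cyclohexyl Ether Scaffold

The compounds below may be only part of what the source reports. "The series", "measured", "known", "first", "only" and "open" are said of these compounds alone.

Compound 1 `Cc1ccc(NC(=O)N[C@H]2CC[C@H](Oc3ccc(F)cc3)CC2)cc1` is one of two diaryl ureas measured in a functional assay on CRL2813 cells (Homo sapiens) for cytotoxicity, read by sulforhodamine B assay, with a stated time of 5 days; a higher number here means a weaker inhibitor, a lower number a stronger inhibitor. In this assay compound 1 gives only a limit, > 20000 nM. Compound 2 `O=C(Nc1ccc(F)cc1)N[C@H]1CC[C@H](Oc2ccc(F)cc2)CC1` is the other; in this assay compound 2 gives 20000 nM. Going by the values given here, the one measured step, a number no higher from compound 1 to compound 2 (the limit leaves the size open), shows no readable size, because both values rest at the limit of > 20000 nM in this assay, at which 1 of the 2 values shown sits.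

Compound 3 `O=C(Nc1ccccc1Br)N[C@H]1CC[C@H](Oc2ccc(F)cc2)CC1` has not yet been measured in this assay. It differs from compound 1 in one place: 2-bromophenyl in place of 4-methylphenyl on an amide-type nitrogen. Among the compounds with values here, the only step that bears on this change is the aryl swap recorded in a number no higher from compound 1 to compound 2 (the limit leaves the size open), and it offers no measurable movement. With compound 1 standing at a limit, the starting point itself is open. The account therefore expects no step beyond the scatter, a number no higher from compound 1 to compound 3 (the limit leaves the size open), and anticipates that compound 3 remains weak. It is estimated that compound 3 gives 20000 nM in this assay, with a range from 8000 nM to 50000 nM, and a fair chance that only a limit is reported once more.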

Compound 3, half-maximal inhibitory concentration: 7700 nM
Compound 3: the middle estimate sits 2.6-fold (0.41 log units) above what was measured; measured number outside the range, below it.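

The aryl group on this amide-type nitrogen can move the number in this assay, which the two earlier compounds could not show. Going by these compounds alone, replacing 4-methylphenyl with 2-bromophenyl gives an at least 2.5-fold lower number from compound 1 to compound 3 (0.41 log units; beyond the scatter), and replacing 4-fluorophenyl with 2-bromophenyl gives a 2.6-fold lower number from compound 2 to compound 3 (0.41 log units; beyond the scatter), so compound 3 is the first of these ureas to separate from both of the others by more than the scatter. The first of these steps has no upper end to its size because compound 1 gives only a limit of the assay: the limit of > 20000 nM in this assay, at which 1 of the 3 values shown sits.

What the compounds shown leave open is whether the bromine or its place on the ring carries the step, since 2-bromophenyl differs from the groups it replaces in both the atom and where it sits, and only a pair such as 4-bromophenyl against 2-bromophenyl, or 2-methylphenyl against 4-methylphenyl, could pull the two apart. They also leave open how far the step extends to other groups at this place, such as 2-chlorophenyl or 2-methoxyphenyl, and why the number moves at all.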